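The source may report more compounds than this note shows. Statements on the series, on what has been measured and on what is new or still open speak of the compounds shown alone.

Read in a functional assay on SK-OV-3 cells (Homo sapiens) for inhibition, read by sulforhodamine B assay, with a stated time of 48 h (on this read-out lower numbers stand for stronger inhibition of growth and higher numbers for weaker inhibition of growth), so far:
- compound 1 `O=C(Cc1csc2nc(-c3ccc(Br)cc3)cn12)N/N=C/c1ccccc1` gives 66100 nM
- compound 2 `O=C(Cc1csc2nc(-c3ccc(Br)cc3)cn12)N/N=C/c1ccccc1O` gives 12900 nM

Among the measured compounds shown here, compound 2 holds the lower of the two numbers, and compound 1 is its only neighbour. Next comes compound 3 `O=C(Cc1csc2nc(-c3ccc(Br)cc3)cn12)N/N=C/c1ccc(O)cc1`, which has the same atoms joined differently (4-hydroxyphenyl in place of 2-hydroxyphenyl on a carbon with a double bond to nitrogen). For the measured compounds named here, one measured step bears on this change (a 5.1-fold lower number from compound 1 to compound 2 (0.71 log units; beyond the scatter)), and it is modest and beyond the scatter. Going by the values given here, it shows what adding the hydroxy did, but no measured pair shows what relocating it does, so it sets a scale and not a direction. Part of that gain may be lost, so a smaller step towards a higher number is expected, probably not clearly beyond the scatter (a 1.7-fold higher number from compound 2 to compound 3 (0.23 log units; within the scatter)). Compound 3 is estimated at 22000 nM (range 7000 nM to 65000 nM).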

Compound 3, concentration for 50% growth inhibition: 52500 nM
For compound 3 the middle estimate is 2.4-fold (0.38 log units) below the measured one; measured number inside the range.
By their numbers in this assay, from the lowest: compound 2; then compounds 3 and 1 (each within the scatter of the next).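

In this assay, exchanging 2-hydroxyphenyl for 4-hydroxyphenyl on the carbon with a double bond to nitrogen gives a 4.1-fold higher number from compound 2 to compound 3 (0.61 log units; beyond the scatter), so at this place the location of the hydroxy on the ring counts and not only its presence. The lower number seen with 2-hydroxyphenyl, a 5.1-fold lower number from compound 1 to compound 2 (0.71 log units; beyond the scatter), does not carry over to 4-hydroxyphenyl, which shows a 1.3-fold lower number from compound 1 to compound 3 (0.10 log units; within the scatter) and so no change that can be told from the unsubstituted phenyl. No measurement at hand accounts for this difference between the two hydroxyphenyl groups.

On these data alone, whether a methoxy or an amine in place of the hydroxy on the 2-hydroxyphenyl would hold the lower number remains open. As far as these compounds go, compound 2 gives 12900 nM, and it is also open whether any other group at this place on the shared core would bring a clearly lower number.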